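This account rests on a few compounds, and the source may have more. Where it says the series, first, only, none or still open, it means among the compounds named here.

Series notes. Compound 1 `CC(C)n1ncc2c(C(=O)Nc3c(F)cccc3F)cc(-c3cccs3)nc21` is read in an ADME assay on LLC-MK2 cells (Macaca mulatta) for cytotoxicity, read by spectrophotometry and crystal violet staining, with a stated time of 4 days; on this read-out lower numbers stand for higher toxicity in this test and higher numbers for lower toxicity in this test. For compound 1 this assay reports only a limit, > 200000 nM, and no number; the limit in question is the limit of > 200000 nM in this assay, at which 1 of the 2 values shown sits. Compound 2 `CC(C)n1ncc2c(C(=O)Nc3ccc(F)c(S(N)(=O)=O)c3)cc(-c3cccs3)nc21` gives 50000 nM in this assay. Compound 3 `CC(C)n1ncc2c(C(=O)Nc3ccc(F)cn3)cc(-c3cccs3)nc21` is not yet measured in this assay. It differs from compound 1 by 5-fluoropyridin-2-yl in place of 2,6-difluorophenyl on an amide-type nitrogen. Among the measured compounds shown here, no step between two measured compounds is available in this set, so the change itself carries no measured size. The expected step of an at least 1.3-fold lower number from compound 1 to compound 3 (0.12 log units; that floor lies within the scatter) is none beyond the scatter. Compound 3 is estimated at 150000 nM in this assay, within 50000 nM to 400000 nM, quite possibly again only as a limit.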

Compound 3, half-maximal cytotoxic concentration: > 200000 nM
Compound 3: no number, only a limit (the forecaster's own chance of this, stated with the estimate: 55%); middle value at least 1.3-fold (0.12 log units) from the limit.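

Compound 1 and compound 3 both give only a limit and no number, so no step between them can be read: the limit of > 200000 nM in this assay, at which 2 of the 3 values shown sit.

As far as these compounds go, whether 5-fluoropyridin-2-yl in place of 2,6-difluorophenyl shifts the read-out in this assay at all, and by how much, stays open.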